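The source may report more compounds than this note shows. Statements on the series, on what has been measured and on what is new or still open speak of the compounds shown alone.

In a toxicity assay on HT-29 cells (Homo sapiens) for cytotoxicity (on this read-out lower numbers stand for higher toxicity in this test and higher numbers for lower toxicity in this test), two compounds sharing one core have been measured so far. Compound 1 `CCn1nc(C(=O)N[C@H]2COc3ccccc3N(C)C2=S)nc1Cc1ccccc1` gives > 100000 nM, which is a limit of the assay and not a number. Compound 2 `CCCCn1nc(C(=O)N[C@H]2COc3ccccc3N(C)C2=S)nc1Cc1ccccc1` gives > 100000 nM, which is also a limit and not a number. Both therefore sit at the same point, (the limit of > 100000 nM in this assay, at which 2 of the 2 values shown sit), and neither has a true value on the scale.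

Compound 3 `CC(C)CCn1nc(C(=O)N[C@H]2COc3ccccc3N(C)C2=S)nc1Cc1ccccc1` differs from compound 2 by methyl in place of hydrogen on a saturated chain carbon bound to two saturated chain carbons. In words, this is methyl in place of hydrogen on a saturated chain carbon bound to two saturated chain carbons, so butyl becomes isopentyl.

Going by the values given here, the one measured step that bears on this change is a step that the two limits leave unreadable from compound 1 to compound 2. It also enlarges this chain, but its size cannot be read, so it offers no number to carry forward. It gives no sign that enlarging the chain moves the read-out, so no step beyond the usual scatter is expected. The expected change is a number no higher from compound 2 to compound 3 (the limit leaves the size open). For compound 3 the estimate is 100000 nM, with an expected range from 40000 nM to 200000 nM, and the assay will most likely report only a limit.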

Compound 3, half-maximal cytotoxic concentration: > 100000 nM
Compound 3 ended at the assay's limit; the forecaster's own chance of this, stated with the estimate: 85%; the middle value lies on the limit itself.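

In this assay compound 3 gives > 100000 nM as a limit of the assay and not a number. Going by these compounds alone, no step among compound 1, compound 2 and compound 3 can therefore be read: the limit of > 100000 nM in this assay, at which 3 of the 3 values shown sit. The compounds shown leave open how toxic any of the three is to these cells, and whether changing this chain moves the read-out at all.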